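From Benzyloxy to Cyclopropylmethoxy on a Shared Core

The compounds below may be only part of what the source reports. "The series", "measured", "known", "first", "only" and "open" are said of these compounds alone.

Of the compounds shown here, two sharing one core have so far been measured in a physicochemical assay for lipophilicity, read by HPLC, at pH 7.4; on this read-out lower numbers stand for lower lipophilicity and higher numbers for higher lipophilicity. Compound 1 `O=C(O)CCn1c(=O)oc2cc(Cl)c(Cl)cc21` gives 1.61. Compound 2 `O=C(O)CCn1c(=O)oc2cc(OCc3ccccc3)c(Cl)cc21`, with benzyloxy in place of chloro on an aromatic carbon, gives 2.71, the higher of the two numbers.

Compound 3 `O=C(O)CCn1c(=O)oc2cc(OCC3CC3)c(Cl)cc21` differs from compound 2 in one place: cyclopropyl in place of phenyl on a saturated chain carbon bound to an oxygen on an aromatic ring. Cyclopropyl stands in place of phenyl on a saturated chain carbon bound to an oxygen on an aromatic ring, so benzyloxy becomes cyclopropylmethoxy.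

Among the compounds with values here, only one measured step bears on this change: a number 1.10 log units higher from compound 1 to compound 2 (beyond the scatter). Within the data shown here, it is an indirect guide, as it exchanged chloro for benzyloxy, and no measured pair exchanges phenyl for cyclopropyl. Compound 3 keeps the oxygen and the chain carbon, and only the phenyl is replaced. A moderate fall in this assay is therefore expected, smaller than the rise seen in that one step and opposite to it. The expected change is a number 0.51 log units lower from compound 2 to compound 3 (beyond the scatter). For compound 3 the estimated value is 2.2, within an expected range from 1.85 to 2.55.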

Compound 3, distribution coefficient: 2.09
Compound 3: the middle estimate sits 0.11 log units above what was measured, within the range that was stated.
By their numbers in this assay, from the lowest: compound 1; then compound 3; then compound 2.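

In this assay the exchange of phenyl for cyclopropyl on a saturated chain carbon bound to an oxygen on an aromatic ring now has a direct measurement, a number 0.62 log units lower from compound 2 to compound 3 (beyond the scatter), with the oxygen and the chain carbon left in place. The step of a number 0.48 log units higher from compound 1 to compound 3 (beyond the scatter) shows that part of the rise seen with benzyloxy remains once the phenyl has gone, and a benzene ring is not required for the number to stand above that of compound 1. No independent measurement accounts for the size of either step, so these compounds record the changes without explaining them.

The three compounds leave open how the number would respond to other groups on the same chain carbon, such as cyclohexyl, which would show whether a larger saturated ring moves it back towards that of compound 2, or an amine. They also leave open whether the steps seen here would keep their size if the remaining chloro or the propanoic acid chain of the shared core were replaced.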